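Taking a chlorine off a series at the limit

The source may hold more compounds than are shown below. What is called first, only, known or untested is meant among the compounds shown, and "the series" means these compounds.

Values from an ADME assay on HCT-116 cells (Homo sapiens) for cytotoxicity, read by CellTiter-Glo, with a stated time of 72 h (on this read-out higher numbers stand for weaker inhibition and lower numbers for stronger inhibition), for the three measured compounds:
Compound 1 `CC1CCN(C2CCN(S(=O)(=O)c3cccc(C(F)(F)F)c3)CC2)CC1` gives > 5000 nM as a limit
Compound 2 `CC1CCN(C2CCN(S(=O)(=O)c3cccc(Cl)c3)CC2)CC1` gives > 5000 nM as a limit
Compound 3 `CC1CCN(C2CCN(S(=O)(=O)c3cccc(-c4ccc(Cl)cc4)c3)CC2)CC1` gives > 5000 nM as a limit

Compound 3 stands with > 5000 nM as its entry in this assay and that entry is a limit. Among the measured compounds shown here, the whole set looks the same, with the limit of > 5000 nM in this assay, at which 3 of the 3 values shown sit, as the only evidence on the measured steps.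

Compound 4 `CC1CCN(C2CCN(S(=O)(=O)c3cccc(-c4ccccc4)c3)CC2)CC1` is the next case. It differs from compound 3 by hydrogen in place of chloro on an aromatic carbon and in words this is hydrogen in place of chloro on an aromatic carbon, para to a large group, so that 4-chlorophenyl becomes phenyl.

The nearest measured change is a step that the two limits leave unreadable from compound 2 to compound 3 and the other two are a step that the two limits leave unreadable from compound 1 to compound 3 and a step that the two limits leave unreadable from compound 1 to compound 2 in the same series. None of them offers a size to carry over. No step beyond the scatter is therefore expected in this assay and no direction can be named. The expected step is a step that the limit leaves unreadable from compound 3 to compound 4 and it rests on the structural change alone. For compound 4 the estimated value is 8000 nM with an expected range from 4000 nM to 20000 nM and a limit is the most likely report.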

Compound 4, half-maximal inhibitory concentration: > 5000 nM
Compound 4: no number, only a limit; the forecaster's own chance of this, stated with the estimate: 85%; the middle value does not contradict the limit.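

In this assay compound 4 gives > 5000 nM, which is a limit and not a number. No step can be read between it and compound 1, compound 2 or compound 3, whose entries are also limits: the limit of > 5000 nM in this assay, at which 4 of the 4 values shown sit.

The compounds shown leave open how far these four differ from one another in this assay, and at what concentration any of them would reach half-maximal inhibition.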